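Four Compounds and Their Toxicity on Vero Cells

The compounds below may be only part of what the source reports. "The series", "measured", "known", "first", "only" and "open" are said of these compounds alone.

All four compounds share one core and differ only at two points. Compound 1 `O=C(N/N=C/c1c(-c2cc3ccccc3oc2=O)[nH]c2ccccc12)c1ccccc1F` carries a 2-fluorophenyl on the carbonyl carbon. Compound 2 `O=C(N/N=C/c1c(-c2cc3ccccc3oc2=O)[nH]c2ccccc12)c1cccc(Br)c1` differs from it by 3-bromophenyl in place of 2-fluorophenyl on a carbonyl carbon. Compound 3 `O=C(N/N=C/c1c(-c2cc3ccc(Br)cc3oc2=O)[nH]c2ccccc12)c1ccccc1F` differs from compound 1 by bromo in place of hydrogen on an aromatic carbon. Going by the values given here, compound 4 `O=C(N/N=C/c1c(-c2cc3ccc(Br)cc3oc2=O)[nH]c2ccccc12)c1cccc(Br)c1` carries both changes at once; it differs from compound 3 by 3-bromophenyl in place of 2-fluorophenyl on a carbonyl carbon, which is the same change as the one from compound 1 to compound 2, made at the same place.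

In a toxicity assay on Vero cells (Chlorocebus sabaeus) for inhibition, read by MTT assay, with a stated time of 48 h (on this read-out higher numbers stand for weaker inhibition and lower numbers for stronger inhibition), compound 1 gives > 200000 nM, which is a limit of the assay and not a number. In this assay compound 2 gives > 200000 nM, again a limit. In this assay compound 3 gives > 200000 nM, also a limit. So the data show a step that the two limits leave unreadable from compound 1 to compound 2 and a step that the two limits leave unreadable from compound 1 to compound 3. Among the compounds with values here, all three measured values sit at the limit of > 200000 nM in this assay, at which 3 of the 3 values shown sit, so no step among them can be sized.

For compound 4 the step is expected to be a step that the limit leaves unreadable from compound 3 to compound 4, because the same change from compound 1 to compound 2 gave a step that the two limits leave unreadable from compound 1 to compound 2 with both compounds at the limit of > 200000 nM in this assay, at which 3 of the 3 values shown sit. Compound 4 is therefore expected to give about 300000 nM, with a likely range from 150000 nM to 800000 nM, and most probably this assay will again report only a limit for compound 4 rather than a number.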

Compound 4, half-maximal inhibitory concentration: > 200000 nM
Compound 4 was reported as a limit (the forecaster's own chance of this, stated with the estimate: 85%); the middle value does not contradict the limit.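

In this assay compound 4 gives > 200000 nM and this is a limit, not a number. The steps to compound 4 from compound 3 and from compound 2 therefore cannot be read, because every value is a limit: the limit of > 200000 nM in this assay, at which 4 of the 4 values shown sit.

The compounds shown leave open at what concentration in this assay any of the four compounds would show inhibition, and whether either change alters that concentration at all.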